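The compounds below may be only part of what the source reports. "The series", "measured", "known", "first", "only" and "open" are said of these compounds alone.

Going by the values given here, compound 1 `O=C(NC1CCN(Cc2ccc(OC3CCNCC3)c(Br)c2)CC1)c1cccs1` gives 130 nM in an assay on HEK293 cells for displacement of a labelled ligand from Urotensin-2 receptor (Homo sapiens), read by fluorescence, with a stated time of 90 min (on this read-out higher numbers stand for weaker inhibition and lower numbers for stronger inhibition), and stands lowest of the two numbers so far; its nearest neighbour, compound 2 `O=C(NC1CCN(Cc2ccc(OC3CCNCC3)c(Br)c2)CC1)c1ccco1`, gives 770 nM, a change that is a 5.9-fold higher number from compound 1 to compound 2 (0.77 log units; beyond the scatter). Compound 3 `N#Cc1ccc2cc(C(=O)NC3CCN(Cc4ccc(OC5CCNCC5)c(Br)c4)CC3)sc2c1` carries 6-cyano-1-benzothiophen-2-yl in place of thiophen-2-yl on a carbonyl carbon. Among the compounds with values here, only the step from compound 1 to compound 2 bears on this position, and it shows that exchanging the ring on the carbonyl carbon shifts the number beyond the scatter; no measured step covers a fused ring or a nitrile at this place. A step of a 3.3-fold lower number from compound 1 to compound 3 (0.51 log units; beyond the scatter) toward stronger inhibition is expected for compound 3. Compound 3 is therefore estimated at 40 nM, within 8 nM to 200 nM.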

Compound 3, half-maximal inhibitory concentration: 80 nM
The estimate for compound 3 lay 2.0-fold (0.30 log units) below the measured number; the range from low to high includes it.
By their numbers in this assay, from the lowest: compounds 3 and 1 (each within the scatter of the next); then compound 2.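

In this assay, 6-cyano-1-benzothiophen-2-yl in place of thiophen-2-yl gives a 1.6-fold lower number from compound 1 to compound 3 (0.21 log units; within the scatter), so this position accepts a fused six-membered aromatic ring carrying a nitrile with no change beyond the scatter. In place of furan-2-yl, the same group gives a 9.6-fold lower number from compound 2 to compound 3 (0.98 log units; beyond the scatter), leaving compound 2 apart from the other two. No supporting data on the cause of these differences are available. On these data alone, the fused ring and the nitrile enter together, so their separate contributions remain open. The unsubstituted 1-benzothiophen-2-yl group, or an amine in place of the nitrile, would bear on this.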